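The source may report more compounds than this note shows. Statements on the series, on what has been measured and on what is new or still open speak of the compounds shown alone.

Of the compounds shown here, three sharing one core have been measured in a functional assay, read by spectrophotometry, with a stated time of 2 h; a higher number here means a weaker inhibitor, a lower number a stronger inhibitor. Compound 1 `CC(C)[C@@H]1CC[C@@H](C)C[C@@]12N(C)C(=O)[C@@H]1[C@H]3C(=O)N(C)C(=O)[C@H]3ON12` gives 2160 ug/mL. Compound 2 `CC(C)[C@@H]1CC[C@@H](C)C[C@@]12N(C)C(=O)[C@@H]1[C@H]3C(=O)N(c4ccccc4)C(=O)[C@H]3ON12`, carrying a phenyl in place of the methyl on the amide-type nitrogen in the ring, gives 2310 ug/mL; the step of a 1.1-fold higher number from compound 1 to compound 2 (0.03 log units; within the scatter). Compound 3 `COc1ccc(N2C(=O)[C@H]3[C@H](ON4[C@@H]3C(=O)N(C)[C@@]43C[C@H](C)CC[C@H]3C(C)C)C2=O)cc1` gives 990 ug/mL, the lowest of the three numbers, since a 2.2-fold lower number from compound 1 to compound 3 (0.34 log units; beyond the scatter) and a 2.3-fold lower number from compound 2 to compound 3 (0.37 log units; beyond the scatter).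

Compound 4 `CC(C)[C@@H]1CC[C@@H](C)C[C@@]12N(C)C(=O)[C@@H]1[C@H]3C(=O)N(c4ccc5ccccc5c4)C(=O)[C@H]3ON12` differs from compound 3 in one place: naphthalen-2-yl in place of 4-methoxyphenyl on an amide-type nitrogen in a ring. Among the measured compounds shown here, two measured steps bear on this. The step from compound 2 to compound 3 shows that adding the methoxy lowered the number modestly, so taking it away again may be expected to raise it by a similar amount. The step from compound 1 to compound 2 shows that a bare aryl ring on this nitrogen made no difference beyond the scatter. For the measured compounds named here, no compound carries a second fused aromatic ring, so that part of the change is untested. Compound 4 is therefore expected to show a 1.8-fold higher number from compound 3 to compound 4 (0.26 log units; within the scatter), a modest rise in this assay. The estimate for compound 4 is 1800 ug/mL, with a range from 900 ug/mL to 3600 ug/mL.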

Compound 4, half-maximal inhibitory concentration: 2680 ug/mL
Compound 4: middle estimate off by 1.5-fold (0.17 log units), on the low side, and the stated range covers the measured number.
By their numbers in this assay, from the lowest: compound 3; then compounds 1, 2 and 4 (each within the scatter of the next).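

With a second fused aromatic ring on the amide-type nitrogen, the number stays level with those of the simpler groups, showing a 1.2-fold higher number from compound 2 to compound 4 (0.06 log units; within the scatter) and a 1.2-fold higher number from compound 1 to compound 4 (0.09 log units; within the scatter), so methyl, phenyl and naphthalen-2-yl cannot be told apart at this position. Adding aromatic carbon atoms to the group on this nitrogen therefore does not reproduce what 4-methoxyphenyl does: the change shows a 2.7-fold higher number from compound 3 to compound 4 (0.43 log units; beyond the scatter), and compound 3 now stands beyond the scatter of all three other compounds, the one clear outlier of the set. Nothing measured on these compounds accounts for why compound 3 stands apart.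

On these data alone, whether the lower number is special to methoxy remains open, since a hydroxyl, an amine or a carboxylic acid in its place on the phenyl ring could give a different result. As far as these compounds go, it is also open whether a longer chain such as butyl or a benzyl group on this nitrogen would stay level with methyl.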